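Trifluoromethyl Core: Fluoro to Chloroacetamide at the Para Position

The compounds below may be only part of what the source reports. "The series", "measured", "known", "first", "only" and "open" are said of these compounds alone.

Compound 1 `Fc1ccc(-c2nc3cc(C(F)(F)F)ccc3[nH]2)cc1` stands highest of the two numbers in an ADME assay on MDBK cells (Bos taurus) for cytotoxicity, read by MTT assay, with a stated time of 96 h (on this read-out higher numbers stand for lower toxicity in this test and lower numbers for higher toxicity in this test), giving 19000 nM. Its nearest neighbour is compound 3 `COc1ccc(-c2nc3cc(Cl)c(Cl)cc3[nH]2)cc1`, which in this assay gives 2500 nM, a lower number beyond the scatter of the test. Compound 2 `COc1ccc(-c2nc3cc(C(C)=O)ccc3[nH]2)c(OC)c1OC` in this assay gives only a limit, > 100000 nM, and not a number (the limit of > 100000 nM in this assay, at which 1 of the 3 values shown sits).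

Compound 4 `O=C(CCl)Nc1ccc(-c2nc3cc(C(F)(F)F)ccc3[nH]2)cc1` is not yet measured in this assay. It differs from compound 1 in one place (((chloromethyl)carbonyl)amino in place of fluoro on an aromatic carbon), the new group sitting on an aromatic carbon of a six-membered aromatic ring of carbon only, para to a large group. No measured pair shows this change, so the data give no cause for any move.

In this assay the step is expected to be a 2.7-fold lower number from compound 1 to compound 4 (0.43 log units; beyond the scatter), a modest move toward a lower number. Compound 4 is therefore estimated at 7000 nM in this assay, within a range of 1500 nM to 35000 nM.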

Compound 4, half-maximal cytotoxic concentration: 17000 nM
Estimate against measurement, compound 4: 2.4-fold (0.39 log units) below; the measured number falls inside the stated range.
By their numbers in this assay, from the lowest: compound 3; then compounds 4 and 1 (each within the scatter of the next). At a limit, above all of these: compound 2.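

Among these compounds, on the core of compound 1, in this assay, putting ((chloromethyl)carbonyl)amino in place of fluoro on an aromatic carbon, para to a large group, gives a 1.1-fold lower number from compound 1 to compound 4 (0.05 log units; within the scatter) and is the first step measured between compounds that differ in one place. At this position, on this core, a group of 5 heavy atoms that brings a hydrogen-bond donor and a hydrogen-bond acceptor thus replaces a single fluorine with no change in the read-out beyond the scatter. No measurement shown here bears on this result.

This single pair leaves open whether the same holds on the different cores of compound 2 and compound 3. It also leaves open how an amine, an acetamide without the chlorine or a longer chain would read at this position.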